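Lengthening an Ester Chain in a Cytotoxicity Series

The compounds below may be only part of what the source reports. "The series", "measured", "known", "first", "only" and "open" are said of these compounds alone.

The series opens with compound 1, `Nc1ncnc2c1ncn2CC(O)C(=O)OCCO`, tested in a functional assay on Vero cells (Chlorocebus sabaeus) for cytotoxicity; on this read-out lower numbers stand for higher toxicity in this test and higher numbers for lower toxicity in this test. In this assay compound 1 reaches only the limit > 400 ug/mL, which is a boundary of the assay and not a number. Compound 2, `COC(=O)C(O)Cn1cnc2c(N)ncnc21`, is the same core with hydrogen in place of hydroxymethyl on a saturated chain carbon bound to an oxygen next to a carbonyl group. In this assay compound 2 likewise returns only the limit > 400 ug/mL. The step that the two limits leave unreadable from compound 1 to compound 2 therefore cannot be read from the two boundaries, and compound 2 stands at the limit that both measured values share, described by the limit of > 400 ug/mL in this assay, at which 2 of the 2 values shown sit.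

Compound 3, `CC(C)COC(=O)C(O)Cn1cnc2c(N)ncnc21`, differs from compound 2 in one place: isopropyl in place of hydrogen on a saturated chain carbon bound to an oxygen next to a carbonyl group. For the measured compounds named here, the only measured step, from compound 1 to compound 2, gives no readable size, so no direction can be drawn from it for this change. Because both measured values sit at the limit of > 400 ug/mL in this assay, at which 2 of the 2 values shown sit, compound 3 is expected to stay at or near that boundary, a step of a number no higher from compound 2 to compound 3 (the limit leaves the size open) in this assay. The estimate for compound 3 is 400 ug/mL, within 150 ug/mL to 1000 ug/mL.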

Compound 3, minimum cytotoxic concentration: > 400 ug/mL
Compound 3 ended at the assay's limit; the forecaster's own chance of this, stated with the estimate: 70%; the middle value lies on the limit itself.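

Compound 3 gives only a limit in this assay, as compound 1 and compound 2 do, so none of the steps among these three compounds can be read: the limit of > 400 ug/mL in this assay, at which 3 of the 3 values shown sit.

The compounds shown leave open where the minimum cytotoxic concentration of each one lies, and whether isopropyl in place of hydrogen changes it at all.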